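This account rests on a few compounds, and the source may have more. Where it says the series, first, only, none or still open, it means among the compounds named here.

Among the measured compounds shown here, compound 2 `CCCn1c(=O)[nH]c2nc(-c3ccc(S(=O)(=O)N4CCN(c5ccccc5Br)CC4)cc3)[nH]c2c1=O` gives 0.137 nM in an assay on CHO cells for displacement of a labelled ligand from adenosine receptor A2b (Homo sapiens), read by scintillation counting, with a stated time of 75 min, in the presence of a further agent that is not named here (a lower number here means a stronger inhibitor, a higher number a weaker inhibitor), the lowest of the three numbers measured so far. Compound 1 `CCCn1c(=O)c2[nH]c(-c3ccc(S(=O)(=O)N4CCN(c5ccc(Cl)cc5)CC4)cc3)nc2n(CC)c1=O` gives 4.31 nM in this assay, and compound 3 `CCCn1c(=O)[nH]c2nc(-c3ccc(S(=O)(=O)N4CCN(c5ccccc5)C(C)C4)cc3)[nH]c2c1=O` gives 7.15 nM in this assay; both of these gaps from compound 2 lie beyond the usual scatter of repeated measurements. Compound 4 `CCCn1c(=O)[nH]c2nc(-c3ccc(S(=O)(=O)N4CCN(c5ccc(F)cc5)CC4)cc3)[nH]c2c1=O` has not yet been measured. It differs from compound 2 in one place: 4-fluorophenyl in place of 2-bromophenyl on an amine nitrogen in a ring. For the measured compounds named here, no measured pair shows this change on its own, so its effect cannot be read from the data. A modest step toward a higher number in this assay is expected for compound 4. Compound 4 is expected to give about 1 nM, with a likely range from 0.2 nM to 5 nM. This estimate means a step of a 7.3-fold higher number from compound 2 to compound 4 (0.86 log units; beyond the scatter).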

Compound 4, inhibition constant: 0.644 nM
Compound 4: middle estimate off by 1.6-fold (0.19 log units), on the high side, and the stated range covers the measured number.
By their numbers in this assay, from the lowest: compound 2; then compound 4; then compounds 1 and 3 (each within the scatter of the next).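

Replacing 2-bromophenyl with 4-fluorophenyl on the ring amine nitrogen gives a 4.7-fold higher number from compound 2 to compound 4 (0.67 log units; beyond the scatter) in this assay, so the group at this position does affect the number, and the size of the effect can now be read directly. However, the halogen and its place on the phenyl ring change together, and the step cannot be assigned to either change alone. Nothing available explains the step.

The compounds shown leave open how 4-bromophenyl or 2-fluorophenyl would compare, as either would separate those two changes. They also leave open whether a methoxy-bearing phenyl or a pyridine ring would fit here.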